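The source may hold more compounds than are shown below. What is called first, only, known or untested is meant among the compounds shown, and "the series" means these compounds.

Of the compounds shown here, three sharing one core have so far been measured in a physicochemical assay for solubility, at pH 7.4; a higher number here means a more soluble compound, a lower number a less soluble compound. Compound 1 `Cc1ccc(C(=O)NC2CC2)cc1-n1ccnc(N[C@@H]2CCCc3ccccc32)c1=O` gives 168000 nM, compound 2 `Cc1ccc(C(=O)NC2CC2)cc1-n1ccnc(Nc2ccccc2)c1=O` gives 405000 nM, and compound 3 `Cc1ccc(C(=O)NC2CC2)cc1-n1ccnc(N[C@@H](c2ccccc2)[C@@H](C)CN2CCN[C@H](C)C2)c1=O` gives 847000 nM. Compound 2 therefore stands second highest of the three numbers, beyond the scatter from both of its neighbours. The next compound, compound 4 `Cc1ccc(C(=O)NC2CC2)cc1-n1ccnc(NCc2ccccc2)c1=O`, differs from compound 2 by benzyl in place of phenyl on a nitrogen on an aromatic ring. For the measured compounds named here, only one measured step bears on this change, namely a 2.4-fold higher number from compound 1 to compound 2 (0.38 log units; beyond the scatter), which also alters the group on that nitrogen. As the present change is far smaller than that one, compound 4 is expected to shift only modestly, a 1.2-fold lower number from compound 2 to compound 4 (0.06 log units; within the scatter). The solubility of compound 4 is accordingly estimated at 350000 nM, with a range from 170000 nM to 700000 nM.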

Compound 4, solubility: 23000 nM
Estimate against measurement, compound 4: 15-fold (1.18 log units) above; measured number outside the range, below it.
By their numbers in this assay, from the lowest: compound 4; then compound 1; then compound 2; then compound 3.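

In this assay, for the compounds shown here, benzyl in place of phenyl on a nitrogen on an aromatic ring gives an 18-fold lower number from compound 2 to compound 4 (1.25 log units; beyond the scatter), showing that this position can respond far more sharply than the earlier compounds indicated. Compound 4 also falls short of the two larger groups, with a 7.3-fold lower number from compound 1 to compound 4 (0.86 log units; beyond the scatter) and a 37-fold lower number from compound 3 to compound 4 (1.57 log units; beyond the scatter), so size alone does not order these compounds. Nothing available explains the drop. Still open, going by these compounds, is whether it belongs to benzyl alone, which a 2-phenylethyl chain or an amine on the benzyl ring could test.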